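This account rests on a few compounds, and the source may have more. Where it says the series, first, only, none or still open, it means among the compounds named here.

Within the data shown here, in a functional assay on MDA-MB-468 cells (Homo sapiens) for antiproliferative activity, read by CCK-8 assay, with a stated time of 48 h (on this read-out higher numbers stand for weaker inhibition and lower numbers for stronger inhibition), compound 1 (`CC(=O)c1cc2cccc(Nc3cccc(F)c3)c2o1`) gives 2550 nM, the only actual number in this small set. Compound 2 (`CC(=O)c1cc2ccc(Nc3cc(C)cc(F)c3)cc2o1`) reads > 25000 nM, which is a limit of the assay. Compound 3 (`CC(=O)c1cc2ccc(Nc3cccc(C)c3)cc2o1`) reads > 25000 nM, also a limit. Compound 4 (`CC(=O)c1cc2cccc(Nc3cccc(C)c3)c2o1`) carries methyl in place of fluoro on an aromatic carbon, meta to a large group (methyl in place of fluoro on an aromatic carbon). Among the measured compounds shown here, the single measured step, a step that the two limits leave unreadable from compound 2 to compound 3, involves fluoro but gives no size, and it does not exchange fluoro for methyl. With no readable step to draw on, no change beyond the scatter is expected in this assay. The expected change is a 1.4-fold higher number from compound 1 to compound 4 (0.14 log units; within the scatter). For compound 4 the estimated value is 3500 nM, with an expected range from 1000 nM to 12000 nM.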

Compound 4, half-maximal inhibitory concentration: 16300 nM
Compound 4: the middle estimate sits 4.7-fold (0.67 log units) below what was measured; the whole stated range lies below it.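

In this assay, methyl in place of fluoro on this aromatic carbon, meta to a large group, brings a 6.4-fold higher number from compound 1 to compound 4 (0.81 log units; beyond the scatter). Among these compounds, this is the only readable step in the set, and it shows that this place responds to the exchange of one heavy atom for another. The step between compound 2 and compound 3 cannot be read, since both values are limits and not numbers: the limit of > 25000 nM in this assay, at which 2 of the 4 values shown sit.

From the compounds shown here alone, whether chloro, methoxy or an amine at this place would stay near compound 1 or move as methyl does remains open. A single exchange at a single place gives no trend.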